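Halogenated and methoxylated analogues: predicting a bromophenyl congener

The compounds below may be only part of what the source reports. "The series", "measured", "known", "first", "only" and "open" are said of these compounds alone.

Compound 1 `O=C(COc1ccc(C(=O)/C=C/c2cccc(Cl)c2)cc1)N[C@H]1CCOC1=O`: 4990 nM
Compound 2 `COc1ccccc1/C=C/C(=O)c1ccc(OCC(=O)N[C@H]2CCOC2=O)cc1`: 7240 nM
Compound 3 `O=C1OCC[C@@H]1NC(=S)SCCOc1ccccc1`: > 64000 nM (a limit)

In a functional assay on PC-3 cells (Homo sapiens) for antiproliferative activity, read by MTT assay, with a stated time of 72 h (on this read-out lower numbers stand for stronger inhibition and higher numbers for weaker inhibition), compound 1 gives 4990 nM. Compound 2 is its close relative, and in this assay compound 2 gives 7240 nM. Compound 3 differs more widely in structure, and in this assay compound 3 gives > 64000 nM, which is a limit of the assay rather than a number. Among the two numbers shown, compound 2 carries the higher one, but the gap to compound 1 is small: going from compound 1 to compound 2 gives a 1.5-fold higher number from compound 1 to compound 2 (0.16 log units; within the scatter), so the two are not distinguishable here.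

Compound 4 `O=C(COc1ccc(C(=O)/C=C/c2cccc(Br)c2)cc1)N[C@H]1CCOC1=O` has not yet been measured in this assay. It differs from compound 2 by 3-bromophenyl in place of 2-methoxyphenyl on a double-bonded chain carbon bound to a double-bonded chain carbon. Within the data shown here, the only measured step that speaks to this change is the one from compound 1 to compound 2, an exchange at the same place that stayed within the scatter. Compound 4 carries a halogen at that place, as compound 1 does, so its number is expected to sit close to compound 1 and compound 2 alike, with no step beyond the scatter from compound 2 to compound 4 expected: a 1.4-fold lower number from compound 2 to compound 4 (0.16 log units; within the scatter). Compound 4 is therefore estimated at 5000 nM, with a plausible range from 2000 nM to 12000 nM.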

Compound 4, half-maximal inhibitory concentration: 7890 nM
For compound 4 the middle estimate is 1.6-fold (0.20 log units) below the measured one; low and high end bracket the measured number.
By their numbers in this assay, from the lowest: compounds 1, 2 and 4 (each within the scatter of the next). At a limit, above all of these: compound 3.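

The new compound adds a second exchange at this place, and in this assay 3-bromophenyl in place of 2-methoxyphenyl gives a 1.1-fold higher number from compound 2 to compound 4 (0.04 log units; within the scatter). Among these compounds, it also adds the first direct comparison of two halogens on the same aromatic carbon, where bromo in place of chloro gives a 1.6-fold higher number from compound 1 to compound 4 (0.20 log units; within the scatter). Compounds 1, 2 and 4 therefore cannot be told apart in this assay, so the three substituted phenyl groups shown at this place, which carry chloro, methoxy or bromo, are equally compatible with a micromolar-range number, and neither the swap of one halogen for another nor the swap of a halogen for methoxy registers as a real step.

What the compounds shown leave open is whether any group at this place can move the number beyond the scatter, for instance an amine or a carboxylic acid on the phenyl ring, or a longer chain in place of the ring. No measurement shown bears on why these exchanges leave the number within the scatter.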